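The source may report more compounds than this note shows. Statements on the series, on what has been measured and on what is new or still open speak of the compounds shown alone.

Working notes on the series. In a functional assay on HeLa cells (Homo sapiens) for cytotoxicity, read by MTT assay, with a stated time of 72 h (on this read-out lower numbers stand for stronger inhibition and higher numbers for weaker inhibition), three compounds have been measured so far. Compound 1 (`COC(=O)c1sc2c(C)cccc2c1Nc1cc(OC)c(OC)c(OC)c1`) gives 1730 nM, and compound 2 (`CCOC(=O)c1sc2ccccc2c1Nc1cc(OC)c(OC)c(OC)c1`) gives 3100 nM. Compound 3 (`COC(=O)c1sc2cc(C)ccc2c1Nc1cc(OC)c(OC)c(OC)c1`) gives 0.31 nM, the lowest of the three numbers, and its gap to each of the other two lies well beyond the scatter. It is therefore the most potent compound measured in this assay.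

The next compound is compound 4 (`COC(=O)c1sc2ccccc2c1Nc1cc(OC)c(OC)c(OC)c1`), which has not yet been measured. The change from compound 3 is hydrogen in place of methyl on an aromatic carbon. Among the measured compounds shown here, no step between measured compounds isolates this change, so the series gives no direct measure of it. The expectation rests on the values alone: compound 3 at 0.31 nM stands apart, while compound 1 at 1730 nM and compound 2 at 3100 nM lie far higher. Losing the methyl is expected to move the number up, toward weaker inhibition, and the step is expected to lie well beyond the scatter. The estimated change is a 1900-fold higher number from compound 3 to compound 4 (3.29 log units; beyond the scatter). Compound 4 is expected at about 600 nM, with an estimated range of 40 nM to 6000 nM.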

Compound 4, half-maximal inhibitory concentration: 427 nM
Compound 4: the middle estimate sits 1.4-fold (0.15 log units) above what was measured; measured number inside the range.
By their numbers in this assay, from the lowest: compound 3; then compound 4; then compounds 1 and 2 (each within the scatter of the next).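

Taking the methyl off the aromatic carbon that is meta to a fused ring and para to a fused ring gives a 1400-fold higher number from compound 3 to compound 4 (3.14 log units; beyond the scatter) in this assay, so in this pair nearly all of the low number of compound 3 goes with that one methyl. The same change read at the different aromatic carbon carrying the methyl of compound 1 runs the other way, with a 4.1-fold lower number from compound 1 to compound 4 (0.61 log units; beyond the scatter) as a modest step, so among these compounds the outcome depends on where the methyl sits and not on its presence alone. The ester change, hydrogen in place of methyl on a saturated chain carbon bound to an oxygen next to a carbonyl group, gives a 7.3-fold lower number from compound 2 to compound 4 (0.86 log units; beyond the scatter) and is also modest, far smaller than the step from the methyl in compound 3.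

The compounds shown leave open whether an ethyl group, a methoxy group or a chlorine on the aromatic carbon of compound 3 would keep so low a number, and whether that methyl would act the same way on the ethyl ester of compound 2. Nothing available bears on the origin of these steps.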